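The source may report more compounds than this note shows. Statements on the series, on what has been measured and on what is new or still open speak of the compounds shown alone.

Compound 1 `CCSC1=N[C@@H](C(=O)OC)[C@@H]2C(=O)N(c3ccccc3)C(=O)[C@H]12`: 91%
Compound 2 `CCCCSC1=N[C@@H](C(=O)OC)[C@@H]2C(=O)N(c3ccccc3)C(=O)[C@H]12`: 82%
Compound 3 `COC(=O)[C@H]1N=C(SC(C)C)[C@H]2C(=O)N(c3ccccc3)C(=O)[C@H]21`: 72%

All three compounds share one core and differ only in the group on the sulfur. In a functional assay for inhibition, tested at 100 uM (on this read-out higher numbers stand for more inhibition at the one concentration tested (going by the name of the read-out) and lower numbers for less inhibition), compound 3 gives the lowest of the three numbers; its gap to compound 2 lies within the usual scatter, so those two cannot be ranked, while its gap to compound 1 lies beyond it.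

Compound 4 `COC(=O)[C@H]1N=C(SCc2ccccc2)[C@H]2C(=O)N(c3ccccc3)C(=O)[C@H]21` is not yet measured. It differs from compound 3 in one place: benzyl in place of isopropyl on a sulfur.

For the measured compounds named here, one measured step bears on this change. Lengthening the chain on the sulfur gave a number 9 percentage points lower from compound 1 to compound 2 (within the scatter), a change too small to count. Compound 2 and compound 3, a straight chain against a branched one, also show numbers within the scatter of each other. Both observations suggest that altering the group on the sulfur moves this assay little. Going by the values given here, a benzyl brings an aromatic ring, which none of the measured compounds carries, so the step is less certain; compound 3 is expected to stay close, with a number 2 percentage points lower from compound 3 to compound 4 (within the scatter) expected, and no step beyond the scatter is likely.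

Compound 4 is therefore estimated at 70%, with a range from 50% to 88%.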

Compound 4, a percentage reported as inhibition, at one concentration (the size of the read-out at that concentration, not a potency): 76%
Estimate against measurement, compound 4: 6 percentage points below; the range from low to high includes it.
By their numbers in this assay, from the lowest: compounds 3, 4, 2 and 1 (each within the scatter of the next, the first and the last beyond it).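

In this assay benzyl in place of isopropyl on the sulfur gives a number 4 percentage points higher from compound 3 to compound 4 (within the scatter) and so no change that can be told from the scatter, even though the entering group has 7 heavy atoms against 3 and brings a six-membered aromatic ring of carbon only. For the compounds shown here, until now, the groups on this sulfur, whose other neighbour is a carbon with a double bond to nitrogen, had all been saturated chains without a ring, so compound 4 is the first sign that an aromatic ring can sit at this position and keep this assay within the scatter of compound 3. Nothing shown here gives a reason for this small step.

On these data alone, all the groups on the sulfur so far contain only carbon and hydrogen, so it remains open how this assay would respond to a chain ending in an amine or a carboxylic acid, or to a benzyl carrying a methoxy group on its ring. The read-out also comes from one concentration only, so these compounds leave open how their potencies compare.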